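Piperidinyl for Pyrrolidinyl on the Core of Compound 2

This account rests on a few compounds, and the source may have more. Where it says the series, first, only, none or still open, it means among the compounds named here.

Measured compounds:
compound 1, `CN(c1ccc(Oc2ncnc3ccsc23)cc1)c1nccc(N2CCCCC2)n1`, 49.7%
compound 2, `CN(c1ccc(Oc2ncnc3sccc23)cc1)c1nccc(N2CCCC2)n1`, 31%

Of the compounds shown here, two have been tested so far in a functional assay on MDA-MB-231 cells (Homo sapiens) for inhibition, read by MTT assay, with a stated time of 72 h, tested at 20 uM; on this read-out higher numbers stand for more inhibition at the one concentration tested (going by the name of the read-out) and lower numbers for less inhibition. Compound 1 gives 49.7%, and compound 2 gives 31%, the lower of the two numbers, with a gap that lies beyond the usual scatter. Going by the values given here, the two structures differ in more than one place, so no single step between them can be read off.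

Compound 3, `CN(c1ccc(Oc2ncnc3sccc23)cc1)c1nccc(N2CCCCC2)n1`, keeps the core of compound 2 and carries the change (piperidin-1-yl in place of pyrrolidin-1-yl on an aromatic carbon). Among the compounds with values here, no measured pair isolates this change. In this assay a small rise for compound 3 is expected, since compound 1 carries the same piperidin-1-yl and reaches 49.7%, though on a different core. The expected step is a number 9 percentage points higher from compound 2 to compound 3 (within the scatter), and compound 3 is estimated at 40%, within 25% to 56%.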

Compound 3, a percentage reported as inhibition, at one concentration (the size of the read-out at that concentration, not a potency): 29.3%
Compound 3: middle estimate off by 10.7 percentage points, on the high side; the range from low to high includes it.
By their numbers in this assay, from the lowest: compounds 3 and 2 (each within the scatter of the next); then compound 1.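

Placing piperidin-1-yl for pyrrolidin-1-yl on the aromatic carbon next to the ring nitrogen gives a number 1.7 percentage points lower from compound 2 to compound 3 (within the scatter) in this assay, so on this core the change cannot be told apart from no change at this position. With piperidin-1-yl held constant, the remaining difference, the group on the oxygen on an aromatic ring, gives a number 20.4 percentage points lower from compound 1 to compound 3 (beyond the scatter), which shows that the gap between the first two compounds does not depend on piperidin-1-yl alone. No measured property bears on either step, so neither can be explained.

Going by these compounds, whether the same change would read alike on the core of compound 1 remains open. Also open, on these data alone, is how a morpholin-4-yl ring or an open-chain dimethylamino group would read at this position.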